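The source may report more compounds than this note shows. Statements on the series, on what has been measured and on what is new or still open speak of the compounds shown alone.

This small set of compounds shares a core in which a five-membered aromatic ring with 2 nitrogen carries a trimethoxyphenyl group, and differs only in what sits on one aromatic nitrogen of that ring. Compound 1 `CCn1ccnc1-c1cc(OC)c(OC)c(OC)c1` bears an ethyl group there, and in an ADME assay on HUVEC cells (Homo sapiens) for cytotoxicity, read by MTT assay, with a stated time of 72 h (on this read-out higher numbers stand for weaker inhibition and lower numbers for stronger inhibition), compound 1 gives "not determined" (no result reported). Compound 2 `CCCn1ccnc1-c1cc(OC)c(OC)c(OC)c1` bears a propyl group there, and in this assay compound 2 gives "not determined" (no result reported), so compound 2 stands without a number, and compound 1 is in the same position. Compound 3 `COc1cc(-c2nccn2-c2ccc3[nH]ccc3c2)cc(OC)c1OC` carries an indolyl group on that nitrogen, and in this assay compound 3 gives 46700 nM, which is a weak effect on these cells.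

The step now followed goes from compound 2 to compound 4 `COc1cc(-c2nccn2-c2ccc(Br)cc2)cc(OC)c1OC`. The change is 4-bromophenyl in place of propyl on an aromatic nitrogen. Within the data shown here, there is no measured step between a propyl and an aryl group on this nitrogen, so the size of the step in this assay cannot be taken from the data. Among the measured compounds shown here, the only anchor is compound 3, whose value of 46700 nM in this assay points to weak cytotoxicity for an aryl group on the nitrogen. Compound 4 is therefore expected to give about 40000 nM in this assay, estimated within a range from 12000 nM to 120000 nM.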

Compound 4, half-maximal inhibitory concentration: > 100000 nM
Compound 4: only a limit was reported; the forecaster's own chance of this, stated with the estimate: 25%; middle value at least 2.5-fold (0.39 log units) away from the limit.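

Compound 2 stands without a number in this assay, so no step can be read from it to compound 4. Compound 4 gives > 100000 nM, which is a limit of the assay and not a number. The compounds shown leave open how far the effect on these cells shifts when 4-bromophenyl takes the place of propyl.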